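Hydrogen in place of chloro on compound 2

This account rests on a few compounds, and the source may have more. Where it says the series, first, only, none or still open, it means among the compounds named here.

compound 1 (`CC(C)(C)c1cc(OC(=O)c2ccco2)ccc1O`) half-life < 0.25 h (a limit)
compound 2 (`CC(C)(C)c1cc(OC(=O)c2ccc(Cl)cc2)ccc1O`) half-life < 0.25 h (a limit)

The series is read in an ADME assay on a cell-free system (serum) for metabolic stability; on this read-out lower numbers stand for a shorter-lived compound and higher numbers for a longer-lived compound. Compound 2 stands there only as a limit, with compound 2 at < 0.25 h and no number behind it. Compound 1 is also a limit, at < 0.25 h. Both measured compounds share that position: the limit of < 0.25 h in this assay, at which 2 of the 2 values shown sit.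

The next compound is compound 3 (`CC(C)(C)c1cc(OC(=O)c2ccccc2)ccc1O`) , and the change from compound 2 is hydrogen in place of chloro on an aromatic carbon. In words, this is hydrogen in place of chloro on an aromatic carbon, para to a large group, so that 4-chlorophenyl becomes phenyl.

Among the compounds with values here, the one measured step that bears on this is a step that the two limits leave unreadable from compound 1 to compound 2. It also alters the group on the carbonyl carbon, but it gives no size to carry over.

Since compound 2 gives < 0.25 h as a limit, no readable step is expected in this assay, and another limit reading is the likely result. The estimated change is a step that the limit leaves unreadable from compound 2 to compound 3. For compound 3 the estimate is 0.15 h, with an expected range from 0.06 h to 0.3 h.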

Compound 3, half-life: < 0.25 h
Compound 3 gave a limit, no number; the forecaster's own chance of this, stated with the estimate: 85%; the middle value is on the limit's open side.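

In this assay compound 3 gives < 0.25 h, a limit and not a number. No step among compound 1, compound 2 and compound 3 can be read, as all three share one position: the limit of < 0.25 h in this assay, at which 3 of the 3 values shown sit.

The compounds shown leave open the actual half-life of each, and whether furan-2-yl, 4-chlorophenyl and phenyl on the carbonyl carbon differ at all.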